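The compounds below may be only part of what the source reports. "The series", "measured", "known", "first", "only" and "open" are said of these compounds alone.

Compound 1 `O=C(N1CCCN(Cc2ccc(OCc3ccccc3)cc2)CC1)n1cccn1` and compound 2 `N#Cc1cnn(C(=O)N2CCCN(Cc3ccc(OCc4ccccc4)cc3)CC2)c1` share one core, while compound 3 `CN(CCN(C)C(=O)n1cccn1)Cc1ccc(OCc2ccccc2)cc1` is built on a second core; the difference between the two cores is not broken down here. In an assay on membranes from brain for binding affinity to Monoacylglycerol lipase ABHD6 (Mus musculus), read by fluorescence, with stated times of 1 h and 30 min (on this read-out higher numbers stand for weaker inhibition and lower numbers for stronger inhibition), compound 1 gives 960 nM and compound 2 gives 85 nM. The change from compound 1 to compound 2 is cyano in place of hydrogen on an aromatic carbon, and it produced an 11-fold lower number from compound 1 to compound 2 (1.05 log units; beyond the scatter). In this assay compound 3 gives 530 nM, which sits close to that of compound 1 and well apart from that of compound 2. Compound 4 `CN(CCN(C)C(=O)n1cc(C#N)cn1)Cc1ccc(OCc2ccccc2)cc1` differs from compound 3 by cyano in place of hydrogen on an aromatic carbon, the same change made on the second core. Among the compounds with values here, only this one earlier step is available, so the expectation rests on it alone: compound 4 is expected to show an 11-fold lower number from compound 3 to compound 4 (1.03 log units; beyond the scatter) because the corresponding change gave an 11-fold lower number from compound 1 to compound 2 (1.05 log units; beyond the scatter). Compound 4 is therefore estimated at 50 nM, between 20 nM and 130 nM.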

Compound 4, half-maximal inhibitory concentration: 320 nM
Compound 4: the middle estimate sits 6.4-fold (0.81 log units) below what was measured, outside the stated range (above it).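

On the second core, cyano in place of hydrogen on the aromatic carbon gives a 1.7-fold lower number from compound 3 to compound 4 (0.22 log units; within the scatter) in this assay. The size of the step seen on the core of compound 1 therefore does not carry over to the core of compound 3: the same change on two cores in this assay, an 11-fold lower number (1.05 log units; beyond the scatter) from compound 1 to compound 2 and a 1.7-fold lower number (0.22 log units; within the scatter) from compound 3 to compound 4, 6.8-fold (0.83 log units) apart, beyond the scatter of two such steps With one pair on each core, this shows that the size of this step depends on the core for these compounds, but not which part of the difference between the cores is responsible, nor how any other change would carry across.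

The compounds shown leave open whether another group on that carbon, such as a chlorine atom or a carboxylic acid, would also differ between the two cores.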